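This account rests on a few compounds, and the source may have more. Where it says the series, first, only, none or still open, it means among the compounds named here.

Measured compounds:
compound 1, `COc1cc(CC[C@@H](O)C[C@@H](O)CCc2ccc(O)cc2)ccc1O`, 2810 nM
compound 2, `O=C(CCc1ccc(O)cc1)C[C@@H](O)CCc1ccccc1`, 75700 nM
compound 3, `CC(=O)O[C@H](CCc1ccc(O)c(O)c1)C[C@H](O)CCc1ccc(O)c(O)c1`, 35500 nM

In a functional assay on RAW264.7 cells (Mus musculus) for inhibition, read by spectrophotometry and Griess assay, with a stated time of 24 h (a lower number here means a stronger inhibitor, a higher number a weaker inhibitor), compound 3 gives 35500 nM, the second highest of the three numbers. Its nearest neighbour is compound 2, whose value in this assay is 75700 nM, a gap beyond the scatter; compound 1, with 2810 nM in this assay, stands much further away. None of these three pairs differs in a single place, so no single step can be read from them.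

Compound 4, `CC(=O)O[C@H](CCc1ccc(O)c(O)c1)C[C@H](O)CCc1ccc(O)cc1`, is the unmeasured analogue of compound 3. The change is hydrogen in place of hydroxy on an aromatic carbon. Going by the values given here, no pair among the measured compounds shows this change on its own, so the expectation rests on the closeness of compound 3 and compound 2 and on compound 4 keeping the rest of the structure of compound 3. The step from compound 3 to compound 4 is expected to be small, within the scatter or slightly toward a weaker inhibitor, as a 1.3-fold higher number from compound 3 to compound 4 (0.10 log units; within the scatter). Compound 4 is therefore estimated at 45000 nM in this assay, between 15000 nM and 130000 nM.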

Compound 4, half-maximal inhibitory concentration: 9520 nM
Beside the measured number, compound 4's estimate is 4.7-fold (0.67 log units) above it, outside the stated range (below it).
By their numbers in this assay, from the lowest: compound 1; then compound 4; then compound 3; then compound 2.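

In this assay, hydrogen in place of hydroxy on an aromatic carbon, ortho to a hydroxy group, gives a 3.7-fold lower number from compound 3 to compound 4 (0.57 log units; beyond the scatter) and is the first single change that can be read among these compounds. The hydroxy group at this position is therefore not needed for inhibition here, and the position is not indifferent to the change, since its loss gives a stronger inhibitor. The step covers one end only, as compound 4 keeps its other 3,4-dihydroxyphenyl group, and no evidence accompanies the result to explain it.

As far as these compounds go, whether fluorine, an amine or a carboxylic acid at this position would move the number the same way remains open. So does whether the same change at the remaining 3,4-dihydroxyphenyl group would repeat the step.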